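Isobutyl for cyclobutylmethyl on a hydantoin-like core

A few compounds are considered here, and "the series" means these few. Any claim that something is new, unique, unknown or untested is made for them only; others in the source may bear on it.

Of the compounds shown here, two sharing one core have been measured in an in vitro ADME assay on microsomes from liver (Rattus norvegicus) for metabolic stability, read by LC-MS, using NADPH, tested at 1 uM; a lower number here means that the compound disappears faster, a higher number that the compound lasts longer. Compound 1 `CCN1C(=O)CN(Cc2ccc(-c3cccc(CN4CCCCC4)n3)cc2)C1=O` carries an ethyl group on the ring nitrogen and no fluorine; in this assay compound 1 gives 0.95 h. Compound 2 `O=C1CN(Cc2ccc(-c3ccc(F)c(CN4CCCCC4)n3)cc2)C(=O)N1CC1CCC1` carries a cyclobutylmethyl group on that nitrogen together with a fluorine on the pyridine-type ring, and in this assay compound 2 gives 0.0833 h. Of the two numbers, compound 2 has the lower one, and the gap to compound 1 lies beyond the scatter, so compound 2 is the one that disappears faster here.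

Compound 3 `CC(C)CN1C(=O)CN(Cc2ccc(-c3ccc(F)c(CN4CCCCC4)n3)cc2)C1=O` is not yet measured. It differs from compound 2 in one place: isopropyl in place of cyclobutyl on a saturated chain carbon bound to an amide-type nitrogen in a ring. Nothing else in the structure changes. For the measured compounds named here, no step between measured compounds speaks directly to this change, so any expectation rests on the closeness of the two side groups. Compound 3 is expected to behave much like compound 2, with at most a modest shift toward a longer half-life, a step of a 1.7-fold higher number from compound 2 to compound 3 (0.23 log units; within the scatter) that may well stay within the scatter. For compound 3 the estimated value in this assay is 0.14 h, with a range from 0.06 h to 0.35 h.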

Compound 3, half-life: 0.15 h
Compound 3: middle estimate off by 1.1-fold (0.03 log units), on the low side, and the stated range covers the measured number.
By their numbers in this assay, from the lowest: compounds 2 and 3 (each within the scatter of the next); then compound 1.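

For the compounds shown here, this is the first step in the set that changes only the group on a saturated chain carbon bound to an amide-type nitrogen in a ring. In this assay, replacing cyclobutyl with isopropyl gives a 1.8-fold higher number from compound 2 to compound 3 (0.26 log units; within the scatter), so at this position and with the rest of the structure fixed, the half-life does not tell the open isopropyl group from the cyclobutyl ring. Both compounds are on the fluorinated form of the shared core, which makes this a cleaner reading of the side group than anything compound 1 offers, since compound 1 differs from each of them in two places. No measurement is given that would explain this result or show where on these compounds the loss occurs.

The large gap to compound 1 therefore remains unassigned, and the compounds shown do not separate the contribution of the fluorine from that of the group on the ring nitrogen. They also leave open whether a group of another kind at this position, such as a methoxyethyl chain, an amine-bearing chain or a longer chain such as hexyl, would move the half-life beyond the scatter.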